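Piperidine in place of methylpiperazine on a quinoline amide

A few compounds are considered here, and "the series" means these few. Any claim that something is new, unique, unknown or untested is made for them only; others in the source may bear on it.

Measured so far:
compound 1, `CCN1CCN(c2cc(C)c3cc(NC(=O)c4ccccc4C)ccc3n2)CC1`, 29200 nM
compound 2, `Cc1cc(NCCN2CCN(C)CC2)nc2ccc(NC(=O)c3ccc(Cl)c(Cl)c3)cc12`, 2690 nM
compound 3, `CCN1CCN(c2cc(C)c3cc(NC(=O)c4cccc(Br)c4)ccc3n2)CC1`, 13300 nM

All three were tested in a functional assay on SK-BR-3 cells (Homo sapiens) for antiproliferative activity, read by MTT assay, with a stated time of 72 h; a lower number here means a stronger inhibitor, a higher number a weaker inhibitor. Compound 2 stands lowest of the three numbers: compound 3 lies closest to it, a 2.2-fold lower number from compound 1 to compound 3 (0.34 log units; beyond the scatter) separates compound 1 from compound 3, and compound 1 is furthest from compound 2. Among the compounds with values here, the one measured step, 3-bromophenyl in place of 2-methylphenyl on a carbonyl carbon, changes the amide side of the shared core and not the chain on the ring nitrogen.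

Compound 4, `Cc1cc(NCCN2CCCCC2)nc2ccc(NC(=O)c3ccc(Cl)c(Cl)c3)cc12`, differs from compound 2 only at the end of that chain: piperidin-1-yl in place of 4-methylpiperazin-1-yl on a saturated chain carbon, two bonds along the chain from a nitrogen on an aromatic ring. Within the data shown here, no measured step touches this part of the molecule, so nothing in the data shows how this assay responds to it. Among the measured compounds shown here, with no bearing step, the expectation is a number close to that of compound 2, with any step from compound 2 to compound 4 likely to stay within the scatter.

Compound 4 is therefore estimated at 3000 nM, with a range from 1000 nM to 9000 nM, which means an expected step of a 1.1-fold higher number from compound 2 to compound 4 (0.05 log units; within the scatter).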

Compound 4, half-maximal inhibitory concentration: 1800 nM
Beside the measured number, compound 4's estimate is 1.7-fold (0.22 log units) above it, within the range that was stated.
By their numbers in this assay, from the lowest: compounds 4 and 2 (each within the scatter of the next); then compound 3; then compound 1.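

In this assay, within the data shown here, piperidin-1-yl in place of 4-methylpiperazin-1-yl on a saturated chain carbon gives a 1.5-fold lower number from compound 2 to compound 4 (0.17 log units; within the scatter), the first reading at the end of the chain, since the one earlier step changed only the amide side of the shared core. In this single pair, with the 3,4-dichlorophenyl amide held constant, the end group goes from 7 heavy atoms to 6 and loses one ring hetero atom and one hydrogen-bond acceptor, yet the number stays within the scatter, so the second ring nitrogen and its methyl group are not needed to hold the number at this level. No measurement available here accounts for this result.

As far as these compounds go, it remains open whether a morpholine or a dimethylamino group at the end of the chain, or a longer chain between the two nitrogens, would stay as close in this assay. From the compounds shown here alone, compounds 1 and 3 differ from compound 4 in more than one place, so it is also open whether the same exchange would give so small a step with a 2-methylphenyl or 3-bromophenyl amide.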